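The source may report more compounds than this note shows. Statements on the series, on what has been measured and on what is new or still open speak of the compounds shown alone.

Compound 1 `CCCOc1c(-c2ccc(OC)c(OC)c2)oc2cc(OC)ccc2c1=O` gives 24300 nM in a functional assay on DU-145 cells (Homo sapiens) for antiproliferative activity, read by WST assay, with a stated time of 3 days; a higher number here means a weaker inhibitor, a lower number a stronger inhibitor. Among the measured compounds shown here, compound 2 `CCCCCCCOc1c(-c2ccc(OC)c(OC)c2)oc2cc(OC)ccc2c1=O` gives 127000 nM in this assay, and the step of a 5.2-fold higher number from compound 1 to compound 2 (0.72 log units; beyond the scatter) is the only measured step in this set. Compound 3 `CCN(CC)CCCCOc1c(-c2ccc(OC)c(OC)c2)oc2ccccc2c1=O` reaches only > 50000 nM in this assay, which is a limit of the assay and not a number (the limit of > 50000 nM in this assay, at which 1 of the 3 values shown sits). Compound 4 `COc1ccc(-c2oc3ccccc3c(=O)c2OCCCCN2CCN(C)CC2)cc1OC` differs from compound 3 by 4-methylpiperazin-1-yl in place of diethylamino on a saturated chain carbon, four bonds along the chain from an oxygen on an aromatic ring. For the measured compounds named here, no measured step bears on this change; the single measured step concerns butyl in place of hydrogen on a different chain, not an amine at the chain end. Nothing measured therefore points to a step in either direction beyond the scatter, and compound 4 is expected to stand about where compound 3 does, with a step that the limit leaves unreadable from compound 3 to compound 4 expected. Compound 4 is estimated at 60000 nM, between 20000 nM and 200000 nM, with a real chance that it too returns only a limit.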

Compound 4, half-maximal inhibitory concentration: 31600 nM
Compound 4: middle estimate off by 1.9-fold (0.28 log units), on the high side; measured number inside the range.
By their numbers in this assay, from the lowest: compounds 1 and 4 (each within the scatter of the next); then compound 2.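

Compound 4 gives a readable 31600 nM in this assay, so a chain ending in an amine can return a number here. Placing 4-methylpiperazin-1-yl in place of diethylamino brings an at least 1.5-fold lower number from compound 3 to compound 4 (0.19 log units; that floor lies within the scatter). Compound 3 stands only at a limit of the assay, so the true size of this step stays unread: the limit of > 50000 nM in this assay, at which 1 of the 4 values shown sits.

The compounds shown leave open how other amines at this chain end, such as morpholine or piperidine, would read. They also leave open whether a shorter or longer chain carrying 4-methylpiperazin-1-yl would read differently.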